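The compounds below may be only part of what the source reports. "The series", "measured", "known", "first", "only" and "open" are said of these compounds alone.

In a functional assay for inhibition, with Homo sapiens as the target (on this read-out lower numbers stand for an effect already at smaller amounts and higher numbers for an effect only at larger amounts of compound), compound 1 (`Nc1ccc(C2=NNC(=O)CC2)cc1`) gives 46.4 ug/mL, while compound 2 (`CCCCC(=O)Nc1ccc(C2=NNC(=O)CC2)cc1`) gives 2.64 ug/mL, the lower of the two numbers. Compound 3 (`O=C1CCC(c2ccc(NC(=O)CCCl)cc2)=NN1`) differs from compound 2 by a single change, chloro in place of ethyl on a saturated chain carbon, two bonds along the chain from a carbonyl carbon. Among the compounds with values here, only one measured step bears on this change, butylcarbonyl in place of hydrogen on a nitrogen on an aromatic ring, which gave an 18-fold lower number from compound 1 to compound 2 (1.24 log units; beyond the scatter). Compound 3 keeps a carbonyl on that nitrogen, as (2-chloroethyl)carbonyl, so most of that large step is expected to remain. Within the data shown here, no measured step shows what a change within the chain does. The expected change is therefore small, a 1.7-fold higher number from compound 2 to compound 3 (0.23 log units; within the scatter), towards a higher number and not beyond the scatter. The estimate for compound 3 is 4.5 ug/mL, with an expected range of 1.3 ug/mL to 16 ug/mL.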

Compound 3, half-maximal effective concentration: 0.98 ug/mL
Compound 3: middle estimate off by 4.6-fold (0.66 log units), on the high side; the whole stated range lies above it.
By their numbers in this assay, from the lowest: compound 3; then compound 2; then compound 1.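

In this assay, within the data shown here, the earlier compounds showed only that adding a carbonyl-bearing chain to the nitrogen matters, whereas chloro in place of ethyl on a saturated chain carbon, two bonds along the chain from a carbonyl carbon, gives a 2.7-fold lower number from compound 2 to compound 3 (0.43 log units; beyond the scatter) and so shows that the make-up of the chain also counts. Against the bare amine, adding the whole chlorine-bearing chain gives a 47-fold lower number from compound 1 to compound 3 (1.68 log units; beyond the scatter) and remains the much larger effect of the two. Nothing available explains why the number falls with this change.

The change swaps two carbons for one chlorine, so the role of the chlorine and the role of chain length remain unseparated. A propylcarbonyl group, or a hydroxyl or an amine in place of the chloro, would help to tell them apart.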